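This account rests on a few compounds, and the source may have more. Where it says the series, first, only, none or still open, it means among the compounds named here.

Of the compounds shown here, two of the shared core have been measured in a functional assay on blood for antagonist activity at thromboxane A2 receptor (Homo sapiens); a lower number here means tighter binding, a higher number weaker binding. Compound 1, `CC(=O)NCc1ccccc1-c1ccc(COC2CC[C@H](N3CCCCCC3)[C@H]2OC/C=C\CCC(=O)O)cc1`, gives 25.1 nM. Compound 2, `O=C(O)CC/C=C\CO[C@H]1C(OCc2ccc(-c3ccc(CO)cc3)cc2)CC[C@@H]1N1CCCCCC1`, gives 3.16 nM. Among the measured compounds shown here, on these two numbers compound 2 stands lowest, and its only neighbour is compound 1; the single step, a 7.9-fold lower number from compound 1 to compound 2 (0.90 log units; beyond the scatter), is the one measured change, and it sits on the same aromatic carbon that is altered next.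

Compound 3, `O=C(O)CC/C=C\CO[C@H]1C(OCc2ccc(-c3ccccc3O)cc2)CC[C@@H]1N1CCCCCC1`, differs from compound 2 in one place: 2-hydroxyphenyl in place of 4-(hydroxymethyl)phenyl on an aromatic carbon. The step from compound 1 to compound 2 shows that exchanging the group on this aromatic carbon can move the number well beyond the scatter, but it was a move between two different substituted phenyl groups, and nothing measured here tells how the 2-hydroxyphenyl compares with the 4-(hydroxymethyl)phenyl. Because compound 2 already stands lowest at 3.16 nM, and the step of a 7.9-fold lower number from compound 1 to compound 2 (0.90 log units; beyond the scatter) shows how much a change here can matter, a modest rise in this assay is expected, a 2.5-fold higher number from compound 2 to compound 3 (0.40 log units; beyond the scatter), with considerable uncertainty. For compound 3 the expected value is 8 nM, with a range from 2.5 nM to 30 nM.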

Compound 3, dissociation constant: 15.9 nM
Compound 3: the middle estimate sits 2.0-fold (0.30 log units) below what was measured; measured number inside the range.
By their numbers in this assay, from the lowest: compound 2; then compounds 3 and 1 (each within the scatter of the next).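

In this assay the 2-hydroxyphenyl does not stand in for the 4-(hydroxymethyl)phenyl (a 5.0-fold higher number from compound 2 to compound 3 (0.70 log units; beyond the scatter)), so this position distinguishes between two groups that have the same counts of hydrogen-bond donors and acceptors and differ by a single heavy atom. The hydroxy and acetamidomethyl groups, by contrast, give numbers within the scatter of each other (a 1.6-fold lower number from compound 1 to compound 3 (0.20 log units; within the scatter)), so a much smaller group on the ring in compound 3 leaves the number where the larger one in compound 1 had it. Among these three compounds, the two 2-substituted phenyl groups sit together and the 4-substituted one gives the lowest number, a pattern that rests on compound 2 alone. Nothing available here bears on the cause of these differences.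

The compounds shown leave open whether the gap follows the place of the substituent or its identity, which a 4-hydroxyphenyl or a 2-(hydroxymethyl)phenyl group would help to separate. They also leave open whether the hydroxyl of the 4-(hydroxymethyl)phenyl group matters, as a 4-(aminomethyl)phenyl or unsubstituted phenyl group could show.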